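Pentyl in place of benzylsulfanyl: expected potency of compound 4

The source may hold more compounds than are shown below. What is called first, only, known or untested is meant among the compounds shown, and "the series" means these compounds.

Compound 3 `CC(C(=O)NCc1ccc(C(C)(C)C)nc1SCc1ccccc1)c1ccc(NS(C)(=O)=O)c(F)c1` gives 4 nM in an assay on cells for antagonist activity at transient receptor potential cation channel subfamily V member 1 (Homo sapiens), read by FLIPR and calcium flux, with a stated time of 6 min; a higher number here means a weaker inhibitor, a lower number a stronger inhibitor. Of the three measured numbers it stands second highest. Compound 2 `CC(C(=O)NCc1ccc(C(C)(C)C)nc1OCc1ccccc1)c1ccc(NS(C)(=O)=O)c(F)c1` gives 4.4 nM, and a 1.1-fold lower number from compound 2 to compound 3 (0.04 log units; within the scatter). Compound 1 `CC(C)COc1nc(C(C)(C)C)ccc1CNC(=O)C(C)c1ccc(NS(C)(=O)=O)c(F)c1` gives 0.6 nM, and a 6.7-fold higher number from compound 1 to compound 3 (0.82 log units; beyond the scatter). Compound 4 `CCCCCc1nc(C(C)(C)C)ccc1CNC(=O)C(C)c1ccc(NS(C)(=O)=O)c(F)c1` is not yet measured; its change from compound 3 is pentyl in place of benzylsulfanyl on an aromatic carbon. The measured step that bears on this change is a 6.7-fold higher number from compound 1 to compound 3 (0.82 log units; beyond the scatter), where a ring-bearing group on this aromatic carbon gave a higher number than isobutoxy; a 7.3-fold higher number from compound 1 to compound 2 (0.87 log units; beyond the scatter) points the same way. Pentyl is a chain with no ring and no acceptor, in this respect nearer to the isobutoxy of compound 1, though no measured compound lacks the oxygen or sulfur at this position, so the size of the recovery is uncertain. For compound 4 the expected step in this assay is a 2.2-fold lower number from compound 3 to compound 4 (0.35 log units; beyond the scatter). The estimate for compound 4 is 1.8 nM, within a range from 0.6 nM to 6 nM.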

Compound 4, inhibition constant: 1.9 nM
Compound 4: the middle estimate sits 1.1-fold (0.02 log units) below what was measured, within the range that was stated.
By their numbers in this assay, from the lowest: compound 1; then compound 4; then compounds 3 and 2 (each within the scatter of the next).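

In this assay, the atom linking the side group to this aromatic carbon can go without losing the activity, and so can the ring: pentyl, which has neither oxygen nor sulfur at this place, gives a 2.1-fold lower number from compound 3 to compound 4 (0.32 log units; beyond the scatter) and a 2.3-fold lower number from compound 2 to compound 4 (0.36 log units; beyond the scatter). Pentyl does not match isobutoxy, however, with a 3.2-fold higher number from compound 1 to compound 4 (0.50 log units; beyond the scatter), so the two ring-free chains are not interchangeable here. No measurement shown accounts for either direction of these steps.

Still open, as far as these compounds go, is whether the remaining gap to isobutoxy follows from the lost oxygen or from the unbranched chain, which an isopentyl chain would separate. An isobutylamino group would show whether a nitrogen link at this aromatic carbon behaves like the oxygen link.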